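The compounds below may be only part of what the source reports. "The series", "measured", "known", "first", "only" and "open" are said of these compounds alone.

Compound 1, `CCCSc1nc2nc(C)cc(N3CC[C@@H](C)[C@@H](N(C)c4ncnc5[nH]ccc45)C3)n2n1`, in a toxicity assay on GES1 cells (Homo sapiens) for inhibition, read by MTT assay, with a stated time of 72 h; on this read-out higher numbers stand for weaker inhibition and lower numbers for stronger inhibition: 67100 nM.
Compound 2, `Cc1cc(N2CC[C@@H](C)[C@@H](N(C)c3ncnc4[nH]ccc34)C2)n2nc(SCc3ccc(C(F)(F)F)cc3)nc2n1`, in this assay: 17300 nM.
Compound 3, `C[C@@H]1CCN(c2cc(-c3ccccc3)nc3ncnn23)C[C@@H]1N(C)c1ncnc2[nH]ccc12`, in this assay: a limit of the assay rather than a number, > 100000 nM.

Compound 2 gives the lowest of the two numbers shown. Its nearest neighbour is compound 1, and the step between the two is a 3.9-fold lower number from compound 1 to compound 2 (0.59 log units; beyond the scatter), which accompanied 4-(trifluoromethyl)phenyl in place of ethyl on a saturated chain carbon bound to a sulfur. The third compound sits at the limit of > 100000 nM in this assay, at which 1 of the 3 values shown sits.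

Compound 4, `Cc1cc(N2CC[C@@H](C)[C@@H](N(C)c3ncnc4[nH]ccc34)C2)n2nc(SCc3ccccc3Br)nc2n1`, is not yet measured. It differs from compound 2 by 2-bromophenyl in place of 4-(trifluoromethyl)phenyl on a saturated chain carbon bound to a sulfur. Within the data shown here, only one measured step touches this same place, the one from the ethyl-bearing to the aryl-bearing compound, and it was modest. The present change swaps one aryl for another at the same place, a smaller move than adding an aryl where a short chain stood, so the number for compound 4 is expected to stay close to that of compound 2, with an expected step of a 1.2-fold higher number from compound 2 to compound 4 (0.06 log units; within the scatter), likely within the scatter. Compound 4 is therefore estimated at 20000 nM, with a range from 8000 nM to 50000 nM.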

Compound 4, half-maximal inhibitory concentration: > 100000 nM
Compound 4: no number, only a limit; the forecaster's own chance of this, stated with the estimate: 10%; middle value at least 5.0-fold (0.69 log units) away from the limit.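

The aryl group at this place, on a saturated chain carbon bound to a sulfur, cannot be swapped freely in this assay: 2-bromophenyl in place of 4-(trifluoromethyl)phenyl gave an at least 5.7-fold higher number from compound 2 to compound 4 (0.76 log units; beyond the scatter), so the lower number of compound 2 does not follow from having just any aryl group there. Set against the ethyl-bearing compound, the same group gave an at least 1.4-fold higher number from compound 1 to compound 4 (0.17 log units; that floor lies within the scatter), and the fall in the number seen with 4-(trifluoromethyl)phenyl in a 3.9-fold lower number from compound 1 to compound 2 (0.59 log units; beyond the scatter) does not appear with 2-bromophenyl. The reading for compound 4 is a limit of the assay and not a number: the limit of > 100000 nM in this assay, at which 2 of the 4 values shown sit.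

The two aryl groups differ both in the substituent they carry and in where it stands on the ring, and the compounds shown cannot separate these two differences. On these data alone, how the number would respond to an unsubstituted phenyl, a longer alkyl chain or an amine at this same place also stays open, as does how far the number of compound 4 actually lies past the limit.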